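The source may report more compounds than this note shows. Statements on the series, on what has been measured and on what is new or still open speak of the compounds shown alone.

In a functional assay on the whole organism for inhibition, with Mus musculus as the target (on this read-out higher numbers stand for an effect only at larger amounts of compound and lower numbers for an effect already at smaller amounts), compound 1 `Cc1ccc(C2CN(C)Cc3c(N)cccc32)cc1` gives about 1.2 mg/kg and compound 2 `CCCCNC(=O)Nc1cccc2c1CN(C)CC2c1ccc(C)cc1` gives about 15 mg/kg. Compound 3 `CCNCC(=O)Nc1cccc2c1CN(C)CC2c1ccc(Cl)cc1`, at 6.4 mg/kg, holds the middle place of the three numbers, lying between those two values. Compound 4 `CCNCC(=O)Nc1cccc2c1CN(C)CC2c1ccc(C)cc1` differs from compound 3 in one place: methyl in place of chloro on an aromatic carbon. Going by the values given here, the only measured step, a 13-fold higher number from compound 1 to compound 2 (1.10 log units; beyond the scatter), is large, but it puts butylcarbamoyl in place of hydrogen on a nitrogen on an aromatic ring, a different change. Among the compounds with values here, no measured pair compares chloro with methyl. A step beyond the scatter is therefore not expected in this assay. The estimated step is a 1.1-fold lower number from compound 3 to compound 4 (0.03 log units; within the scatter). Compound 4 is estimated at 6 mg/kg, with an expected range from 2.5 mg/kg to 15 mg/kg.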

Compound 4, dose for half-maximal effect: 5.6 mg/kg
Estimate against measurement, compound 4: 1.1-fold (0.03 log units) above; low and high end bracket the measured number.
By their numbers in this assay, from the lowest: compound 1; then compounds 4 and 3 (each within the scatter of the next); then compound 2.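

In this assay the change from 4-chlorophenyl to 4-methylphenyl gives a 1.1-fold lower number from compound 3 to compound 4 (0.06 log units; within the scatter) and so leaves the number unmoved at this position, with the ((ethylamino)methyl)carbonyl group on the aromatic amine nitrogen. With the methyl held constant, the nitrogen substituent does move the number: (ethylamino)methyl in place of butylamino gives a 2.7-fold lower number from compound 2 to compound 4 (0.43 log units; beyond the scatter) here, and ((ethylamino)methyl)carbonyl in place of hydrogen gives a 4.7-fold higher number from compound 1 to compound 4 (0.67 log units; beyond the scatter) here. No supporting data bear on the reason for these steps.

Methoxy or trifluoromethyl at this position remains open, as does a longer amine chain on the carbonyl. Whether chloro and methyl also match in compounds with butylcarbamoyl or a free amine is also unresolved.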